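Nitro in place of methyl: cytotoxicity working notes

The source may report more compounds than this note shows. Statements on the series, on what has been measured and on what is new or still open speak of the compounds shown alone.

In an ADME assay on MT4 cells (Homo sapiens) for cytotoxicity, read by MTT assay, with a stated time of 5 days (on this read-out lower numbers stand for higher toxicity in this test and higher numbers for lower toxicity in this test), compound 1 (`COc1cc(Oc2c(C)cc(C)cc2C)cc(Nc2ccc(C#N)cc2)n1`) gives 29000 nM and compound 2 (`COc1cc(Oc2c(C)cc(C)cc2C)cc(Nc2ccc(C)cc2)n1`) gives 35000 nM on this read-out, so the two stand level within the scatter. Compound 3 (`COc1cc(Oc2c(C)cc(C)cc2C)cc(Nc2ccc([N+](=O)[O-])cc2)n1`) follows from compound 2 by one change, 4-methylphenyl to 4-nitrophenyl: nitro in place of methyl on an aromatic carbon on an aromatic carbon, para to a large group. Within the data shown here, only one measured step bears on this place: a 1.2-fold higher number from compound 1 to compound 2 (0.08 log units; within the scatter) for methyl in place of cyano, and it stays within the scatter. Among the measured compounds shown here, no nitro compound has been measured yet, and the evidence is a single pair. No step beyond the scatter is therefore expected in this assay for this change. The expected step is small, a 1.4-fold lower number from compound 2 to compound 3 (0.15 log units; within the scatter) as estimated. For compound 3 the estimate is 25000 nM with an expected range from 9000 nM to 60000 nM in this test.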

Compound 3, half-maximal cytotoxic concentration: 7200 nM
Compound 3: the middle estimate sits 3.5-fold (0.54 log units) above what was measured; measured number outside the range, below it.
By their numbers in this assay, from the lowest: compound 3; then compounds 1 and 2 (each within the scatter of the next).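

In this assay, among these compounds, the group on this aromatic carbon, para to a large group, can shift the number: nitro in place of methyl gives a 4.9-fold lower number from compound 2 to compound 3 (0.69 log units; beyond the scatter), and this is the first step at this place that lies beyond the scatter. Nitro in place of cyano gives a 4.0-fold lower number from compound 1 to compound 3 (0.61 log units; beyond the scatter), so compound 3 stands apart from both compound 1 and compound 2, on the side of higher toxicity in this test. No measurement available here accounts for this separation.

On these data alone, it remains open whether this shift is confined to nitro or would also appear with an amine, a carboxylic acid or a methoxy group at this place. The three compounds also leave open whether the same change would have a similar effect on a different core.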